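This account rests on a few compounds, and the source may have more. Where it says the series, first, only, none or still open, it means among the compounds named here.

Working notes on the step from compound 1 to compound 4. In an ADME assay on LLC-MK2 cells (Macaca mulatta) for cytotoxicity, read by spectrophotometry and crystal violet staining, with a stated time of 4 days (on this read-out lower numbers stand for higher toxicity in this test and higher numbers for lower toxicity in this test), compound 1 `CC(C)n1ncc2c(C(=O)Nc3ccc(F)cc3)cc(-c3cccs3)nc21` gives > 200000 nM, which is a limit of the assay and not a number. Compound 3 `CC(C)n1ncc2c(C(=O)Nc3ccc(F)cc3)cc(-c3ccsc3)nc21` gives > 200000 nM, which is also a limit. For the measured compounds named here, compound 2 `CC(C)n1ncc2c(C(=O)Nc3ccccn3)cc(-c3ccccc3)nc21` gives 12500 nM, the only true number so far. The data are therefore dominated by the limit of > 200000 nM in this assay, at which 2 of the 3 values shown sit, and compound 1 has no exact position on the scale.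

Compound 4 `CC(C)n1ncc2c(C(=O)Nc3ccc(F)cc3F)cc(-c3cccs3)nc21` carries fluoro in place of hydrogen on an aromatic carbon, ortho to a large group and meta to a fluoro group, turning 4-fluorophenyl into 2,4-difluorophenyl. Going by the values given here, the only measured step available is a step that the two limits leave unreadable from compound 1 to compound 3. It involves a different change and supplies no size to carry over. No step beyond the scatter is therefore expected in this assay, and no direction is expected either. The expected outcome is a number no higher from compound 1 to compound 4 (the limit leaves the size open). The estimated value for compound 4 is 200000 nM, with an expected range of 50000 nM to 400000 nM.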

Compound 4, half-maximal cytotoxic concentration: > 200000 nM
Compound 4 gave a limit, no number; the forecaster's own chance of this, stated with the estimate: 65%; the middle value sits exactly at the limit.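

In this assay compound 4 gives > 200000 nM, which is a limit of the assay and not a number. Compound 1 also stands at a limit, so no step can be read between compound 1 and compound 4. The compounds shown leave open whether fluoro in place of hydrogen changes this read-out at all.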